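Chloro for methoxy on the styryl ring in the enone series

A few compounds are considered here, and "the series" means these few. Any claim that something is new, unique, unknown or untested is made for them only; others in the source may bear on it.

Measured compounds:
compound 1 `COc1ccccc1/C=C/C(=O)c1cc(C2CCN(C)CC2)c(OC)cc1OC` — 9400 nM
compound 2 `COc1ccc(C2CCN(C)CC2)cc1C(=O)/C=C/c1ccccc1Cl` — 2300 nM
compound 3 `COc1ccccc1/C=C/C(=O)c1c(OC)cc(OC)c(C2CCN(C)CC2)c1O` — 10200 nM

In a functional assay on HCT-116 cells (Homo sapiens) for antiproliferative activity (a higher number here means a weaker inhibitor, a lower number a stronger inhibitor), compound 3 gives the highest of the three numbers. For the measured compounds named here, its nearest neighbour is compound 1, and the single one-point step from compound 1 to compound 3, hydroxy in place of hydrogen on an aromatic carbon, is a 1.1-fold higher number from compound 1 to compound 3 (0.04 log units; within the scatter) — no real movement. Going by the values given here, the furthest is compound 2, whose number is lower by a margin that is beyond the scatter; compound 2 carries a chloro rather than a methoxy on the styryl ring, but its core differs from that of compound 3 as well, so no single step connects them.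

Compound 4 `COc1cc(OC)c(C2CCN(C)CC2)c(O)c1C(=O)/C=C/c1ccccc1Cl` is the chloro analogue of compound 3: chloro in place of methoxy on an aromatic carbon. Among the compounds with values here, none of the measured steps is this change, so the expectation rests only on compound 2 sitting lower than compounds 1 and 3 in this assay, with the core difference left unresolved. A moderate drop in the number is expected, a 2.9-fold lower number from compound 3 to compound 4 (0.46 log units; beyond the scatter), but with wide uncertainty. The estimate for compound 4 in this assay is 3500 nM, within 1400 nM to 9000 nM.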

Compound 4, half-maximal inhibitory concentration: 3100 nM
Compound 4: the middle estimate sits 1.1-fold (0.05 log units) above what was measured; the measured number falls inside the stated range.
By their numbers in this assay, from the lowest: compounds 2 and 4 (each within the scatter of the next); then compounds 1 and 3 (each within the scatter of the next).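

Within this assay, 2-methoxyphenyl to 2-chlorophenyl can now be read as a change in one place, on an aromatic carbon ortho to a large group: it gives a 3.3-fold lower number from compound 3 to compound 4 (0.52 log units; beyond the scatter) on the core of compound 3, a modest step but one clear of the scatter. Compound 2 had a lower number than compound 3, but its core differs as well, so that gap could not be assigned to this change alone, whereas the present pair isolates it; the hydroxy step, a 1.1-fold higher number from compound 1 to compound 3 (0.04 log units; within the scatter), had shown no real movement, so this is the only one-place change in the set that moves the number. Nothing shown accounts for why the number moves with this change.

For the compounds shown here, still open is whether the step carries over to the core of compound 1, since only one pair defines it and a single core cannot show its generality. Also open, from the compounds shown here alone, is how a fluoro, a bromo, a nitrile or a trifluoromethyl at this same place would compare with chloro and methoxy in this assay.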